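Three Measured Compounds and a Nitro Analogue to Come

A few compounds are considered here, and "the series" means these few. Any claim that something is new, unique, unknown or untested is made for them only; others in the source may bear on it.

The series shares one core and varies the aryl group on a double-bonded chain carbon bound to a double-bonded chain carbon. Compound 1 `COc1ccc(/C=C/C(=O)NCCCCNc2ccnc3cc(Cl)ccc23)cc1` gives 25200 nM in a functional assay on MCF7 cells (Homo sapiens) for antiproliferative activity, read by sulforhodamine B assay, with a stated time of 2 days; on this read-out higher numbers stand for weaker inhibition of growth and lower numbers for stronger inhibition of growth. Compound 2 `O=C(/C=C/c1cccc(F)c1)NCCCCNc1ccnc2cc(Cl)ccc12` gives 14900 nM in this assay, and compound 3 `O=C(/C=C/c1ccc(F)cc1)NCCCCNc1ccnc2cc(Cl)ccc12` gives 12500 nM in this assay. Compound 3 has the lowest of the three numbers, but its nearest neighbour is compound 2 at a step of a 1.2-fold lower number from compound 2 to compound 3 (0.08 log units; within the scatter), and even the widest gap, a 2.0-fold lower number from compound 1 to compound 3 (0.30 log units; within the scatter), stays within the scatter, so the three compounds cannot be separated. The step of a 1.7-fold lower number from compound 1 to compound 2 (0.23 log units; within the scatter) likewise stays within the scatter.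

Compound 4 `O=C(/C=C/c1cccc([N+](=O)[O-])c1)NCCCCNc1ccnc2cc(Cl)ccc12` is the next step. Its change from compound 3 is 3-nitrophenyl in place of 4-fluorophenyl on a double-bonded chain carbon bound to a double-bonded chain carbon. Going by the values given here, none of the measured steps involves a nitrophenyl group; the steps that bear on it are a 2.0-fold lower number from compound 1 to compound 3 (0.30 log units; within the scatter) and a 1.2-fold lower number from compound 2 to compound 3 (0.08 log units; within the scatter), which exchange substituents on the same aryl group and both fall within the scatter. With those two steps in view, compound 4 is expected to show a step of a 1.2-fold higher number from compound 3 to compound 4 (0.08 log units; within the scatter) in this assay, which amounts to no change beyond the scatter. The estimate for compound 4 is therefore 15000 nM, with a range from 5000 nM to 45000 nM.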

Compound 4, concentration for 50% growth inhibition: 59300 nM
Beside the measured number, compound 4's estimate is 4.0-fold (0.60 log units) below it; measured number above the stated range.
By their numbers in this assay, from the lowest: compounds 3, 2 and 1 (each within the scatter of the next); then compound 4.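

Going by these compounds alone, at this place on the chain, the aryl exchange is the first to carry the number beyond the scatter in this assay, and all three steps to the 3-nitrophenyl compound point the same way: a 4.7-fold higher number from compound 3 to compound 4 (0.68 log units; beyond the scatter), a 4.0-fold higher number from compound 2 to compound 4 (0.60 log units; beyond the scatter) and a 2.4-fold higher number from compound 1 to compound 4 (0.37 log units; beyond the scatter). Compound 4 therefore gives weaker inhibition of growth than each of the other three compounds, which themselves stay within the scatter of one another, so this position is not indifferent to the group it carries. The step from compound 2 is the most telling, as 3-fluorophenyl and 3-nitrophenyl differ only in nitro in place of fluoro on an aromatic carbon, so the rise goes with that exchange and not with a move of the group around the ring; nothing measured here explains the rise.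

From the compounds shown here alone, only fluoro, methoxy and nitro groups have been seen on this aryl group, so it remains open whether an amine or a carboxylic acid there would follow compound 4 or stay with compounds 1, 2 and 3. Going by these compounds, it is equally open whether the step from fluoro to nitro would keep its size on a longer chain.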